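The compounds below may be only part of what the source reports. "The series", "measured", "known", "first", "only" and "open" are said of these compounds alone.

Measured so far in a functional assay on HT-29 cells (Homo sapiens) for cytotoxicity, read by MTT assay, with a stated time of 72 h; a higher number here means a weaker inhibitor, a lower number a stronger inhibitor:
Compound 1 `CC(C)(C)OC(=O)N1CCN(c2c(C(=O)NCc3ccc(F)cc3)nc(Br)c3cccnc23)CC1`: > 10000 nM
Compound 2 `N[C@H]1CC[C@H](Nc2c(C(=O)NCc3ccc(F)cc3)nc(Br)c3cccnc23)CC1`: < 1000 nM

Both entries are limits of the assay and not numbers. Compound 2 stands at < 1000 nM, which is a limit, and no exact figure is available for it. Compound 1 stands at > 10000 nM, which is also a limit.

The next compound to be tested is compound 3 `O=C(NCc1ccc(F)cc1)c1nc(Br)c2cccnc2c1N1CCNCC1`. It carries piperazin-1-yl in place of (4-aminocyclohexyl)amino on an aromatic carbon, para to a bromo group: piperazin-1-yl in place of (4-aminocyclohexyl)amino on an aromatic carbon.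

Going by the values given here, no measured step sizes such a change. A moderate shift towards weaker inhibition in this assay is expected, and this is a judgement with wide uncertainty. The expected change is an at least 2.0-fold higher number from compound 2 to compound 3 (0.30 log units; that floor lies within the scatter). For compound 3 the estimated value is 2000 nM, with an expected range of 400 nM to 10000 nM.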

Compound 3, half-maximal inhibitory concentration: 10000 nM
The estimate for compound 3 lay 5.0-fold (0.70 log units) below the measured number, within the range that was stated.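

Going by these compounds alone, on the aromatic carbon para to a bromo group, piperazin-1-yl in place of (4-aminocyclohexyl)amino gives an at least 10-fold higher number from compound 2 to compound 3 (1.00 log units; beyond the scatter) in this assay, the first sized change at this position, and it lies beyond the scatter. Going by these compounds, the step has only a lower bound, and its full size stays open because compound 2 sits at a limit of the assay: the limit of < 1000 nM in this assay, at which 1 of the 3 values shown sits. Compound 1 stands at > 10000 nM, a limit and not a number. Hydrogen in place of tert-butoxycarbonyl on an amine nitrogen in a ring gives a number no higher from compound 1 to compound 3 (the limit leaves the size open).

The compounds shown do not separate the contribution of the ring from that of the amine linking it to the core. A cyclohexylamino group lacking the 4-amino substituent, or a 4-aminopiperidin-1-yl group, at this position would bear on that question.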